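Swapping the Ethynyl for a Methyl on the Core

A few compounds are considered here, and "the series" means these few. Any claim that something is new, unique, unknown or untested is made for them only; others in the source may bear on it.

Measured so far in an assay on HEK293 cells for binding affinity to 5-hydroxytryptamine receptor 7 (Homo sapiens), read by radioligand binding, tested at 1 uM; a lower number here means less inhibition, a higher number more inhibition at the concentration tested (going by the name of the read-out):
- compound 1, `CN1CCCN(CCn2ccc3ccc(Br)cc32)CC1`: 93%
- compound 2, `CN1CCCN(CCn2ccc3ccc(C(F)(F)F)cc32)CC1`: 89%
- compound 3, `C#Cc1ccc2ccn(CCN3CCCN(C)CC3)c2c1`: 79%

All three share one core and differ only in the group on an aromatic carbon. Compound 3 sits below compound 1 by a step beyond the scatter, a number 14 percentage points lower from compound 1 to compound 3 (beyond the scatter), while the step from compound 2 to compound 3, a number 10 percentage points lower from compound 2 to compound 3 (within the scatter), stays within the scatter, so these two cannot be told apart. The step from compound 1 to compound 2, a number 4 percentage points lower from compound 1 to compound 2 (within the scatter), is likewise within the scatter.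

Compound 4, `Cc1ccc2ccn(CCN3CCCN(C)CC3)c2c1`, has not yet been measured. Its change from compound 3 is methyl in place of ethynyl on an aromatic carbon. For the measured compounds named here, no measured step brings in a methyl; the only steps touching compound 3 are a number 14 percentage points lower from compound 1 to compound 3 (beyond the scatter) and a number 10 percentage points lower from compound 2 to compound 3 (within the scatter), which show that changing this group moves the number by a modest amount at most. A methyl in place of ethynyl is therefore expected to give a step of a number 1 percentage points higher from compound 3 to compound 4 (within the scatter) in this assay, with no confident direction. Compound 4 is thus estimated at 80%, with a range from 65% to 92%.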

Compound 4, a percentage reported as inhibition, at one concentration (the size of the read-out at that concentration, not a potency): 62%
Compound 4: the middle estimate sits 18 percentage points above what was measured; measured number outside the range, below it.
By their numbers in this assay, from the lowest: compound 4; then compounds 3, 2 and 1 (each within the scatter of the next, the first and the last beyond it).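

In this assay, for the compounds shown here, methyl is the first group at this aromatic carbon to stand apart from all the others, with a number 17 percentage points lower from compound 3 to compound 4 (beyond the scatter), a number 27 percentage points lower from compound 2 to compound 4 (beyond the scatter) and a number 31 percentage points lower from compound 1 to compound 4 (beyond the scatter). The earlier compounds shown here showed only modest movement at this place, whereas this result shows that the choice of group can matter a good deal more, since replacing bromo with methyl gives a large step and compound 4 has the lowest number of the set. Nothing shown here gives a reason for this drop.

The compounds shown leave open what plain hydrogen at this carbon would give, and whether chloro, ethyl or methoxy would fall closer to methyl or to bromo, which would help show whether methyl is an isolated case or part of a wider trend. On these data alone, it also remains open whether the same order of groups would hold if the seven-membered amine ring of the side chain were replaced by a piperazine or a simple dimethylamine.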